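Swapping the dichlorophenyl on the thiazole of compound 1

The compounds below may be only part of what the source reports. "The series", "measured", "known", "first", "only" and "open" are said of these compounds alone.

Measured compounds:
compound 1 `Cc1c(-c2cc(Cl)cc(Cl)c2)c(C(=O)O)nn1-c1nc(-c2cc(Cl)cc(Cl)c2)c(SC(C)C)s1`: 2000 nM
compound 2 `COc1cc(C#N)cc(-c2c(C)nn(-c3nc(-c4ccc(Cl)c(Cl)c4)c(SC(C)C)s3)c2C(=O)O)c1`: 5200 nM
compound 3 `Cc1nn(-c2nc(-c3ccc(Cl)c(Cl)c3)c(SC(C)C)s2)c(C(=O)O)c1-c1cncc(C#N)c1`: 20000 nM

In a functional assay on BJAB cells (Homo sapiens) for antiproliferative activity, with a stated time of 4 days (a lower number here means that less compound is needed, a higher number that more compound is needed for the effect), compound 1 gives the lowest of the three numbers, with compound 2 nearest and compound 3 furthest. Compound 4 `Cc1c(-c2cc(Cl)cc(Cl)c2)c(C(=O)O)nn1-c1nc(-c2cnn(C)c2)c(SC(C)C)s1` differs from compound 1 by 1-methyl-1H-pyrazol-4-yl in place of 3,5-dichlorophenyl on an aromatic carbon. Among the measured compounds shown here, no measured step touches this position. For the measured compounds named here, the only step available, a 3.8-fold higher number from compound 2 to compound 3 (0.59 log units; beyond the scatter), replaces a carbon-only aromatic ring with a nitrogen-containing one elsewhere on the core and weakens the compound. By that loose analogy, a higher number is expected for compound 4, plausibly larger than the measured step, since two chlorines also leave. Compound 4 is therefore estimated at 8000 nM (range 2000 nM to 40000 nM), an expected step of a 4.0-fold higher number from compound 1 to compound 4 (0.60 log units; beyond the scatter).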

Compound 4, half-maximal effective concentration: "not active" (no number reported)
Compound 4 has no reported number here, so the estimate cannot be set against anything.
By their numbers in this assay, from the lowest: compound 1; then compound 2; then compound 3.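

Among the compounds shown here, compound 4 is reported as "not active" in this assay, without a number, so no step from compound 1 to compound 4 can be read. The compounds shown leave open whether any other group at this position of the thiazole retains the activity of compound 1. No evidence here bears on this result.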